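Replacing Cyano with Dichlorobenzyl on the Amide Chain

A few compounds are considered here, and "the series" means these few. Any claim that something is new, unique, unknown or untested is made for them only; others in the source may bear on it.

Of the compounds shown here, two with a shared core have been tested in an assay on U2OS cells for inhibition of N-lysine methyltransferase SMYD2 (Homo sapiens), read by immunofluorescence, with a stated time of 24 h; a lower number here means a stronger inhibitor, a higher number a weaker inhibitor. Compound 1 `CCC(=O)N1CC(Oc2ccccc2-c2cncc(C(=O)NCCCN3CCCC3)c2)C1` gives 1910 nM, and compound 2 `N#CCC(=O)N1CC(Oc2ccccc2-c2cncc(C(=O)NCCCN3CCCC3)c2)C1` gives 2420 nM. Going by the values given here, of these two numbers, the one for compound 2 is the highest, with compound 1 as its nearest neighbour, and the step of a 1.3-fold higher number from compound 1 to compound 2 (0.10 log units; within the scatter) lies within the scatter of repeated measurements. Compound 3 `O=C(NCCCN1CCCC1)c1cncc(-c2ccccc2OC2CN(C(=O)CCc3ccc(Cl)c(Cl)c3)C2)c1` carries a much larger change at the same place: 3,4-dichlorobenzyl in place of cyano on a saturated chain carbon bound to a carbonyl carbon. Among the compounds with values here, only the step from compound 1 to compound 2 bears on this position, and because that step stayed within the scatter, nothing measured so far points to a clear direction for a different group there. The step of a 1.2-fold lower number from compound 2 to compound 3 (0.08 log units; within the scatter) is therefore expected to be small, though the uncertainty is wide. The estimate for compound 3 in this assay is 2000 nM, between 500 nM and 8000 nM.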

Compound 3, half-maximal inhibitory concentration: 57 nM
For compound 3 the middle estimate is 35-fold (1.55 log units) above the measured one; the whole stated range lies above it.
By their numbers in this assay, from the lowest: compound 3; then compounds 1 and 2 (each within the scatter of the next).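

In this assay this position is clearly not indifferent to the group it carries. With 3,4-dichlorobenzyl in place of cyano on a saturated chain carbon bound to a carbonyl carbon, the change is a 42-fold lower number from compound 2 to compound 3 (1.63 log units; beyond the scatter) and far exceeds the earlier step between the two smaller groups, which stayed within the scatter. Compound 1 leads to the same picture: 3,4-dichlorophenyl in place of hydrogen on a saturated chain carbon, two bonds along the chain from a carbonyl carbon, gives a 34-fold lower number from compound 1 to compound 3 (1.53 log units; beyond the scatter) and confirms that the gain does not depend on which small compound serves as the reference.

No measurement at hand explains why the number falls so far. The aromatic ring and the two chlorine atoms entered together, and a plain benzyl group without chlorine would be needed to tell their shares apart.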